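A few compounds are considered here, and "the series" means these few. Any claim that something is new, unique, unknown or untested is made for them only; others in the source may bear on it.

Measured in a functional assay on MDA-MB-231 cells (Homo sapiens) for antiproliferative activity, with a stated time of 4 days; a lower number here means a stronger inhibitor, a higher number a weaker inhibitor:
Compound 1 `CCCCc1ccc2[nH]c(-c3ccc(OC)cc3)c(C=O)c2c1`: 6.7 nM
Compound 2 `CCCCCc1ccc2[nH]c(-c3ccc(OC)cc3)c(C=O)c2c1`: 5.5 nM
Compound 3 `CCCCc1ccc2[nH]c(-c3ccc(OC)cc3)c(/C=N\C)c2c1`: 6 nM

Compound 3 gives 6 nM, which lies within the usual scatter of both other compounds. Compound 4 `CCCCCc1ccc2[nH]c(-c3ccc(OC)cc3)c(/C=N\C)c2c1` differs from compound 3 by methyl in place of hydrogen on a saturated chain carbon, four bonds along the chain from an aromatic carbon. The same change has been measured once, as a 1.2-fold lower number from compound 1 to compound 2 (0.09 log units; within the scatter). The other measured step, a 1.1-fold lower number from compound 1 to compound 3 (0.05 log units; within the scatter), is the one that separates the two pairs, and it is also small. No change beyond the scatter is therefore expected in this assay. The expected step is a 1.2-fold lower number from compound 3 to compound 4 (0.06 log units; within the scatter). For compound 4 the estimate is 5.2 nM, with an expected range of 2.8 nM to 9.5 nM.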

Compound 4, half-maximal inhibitory concentration: 6 nM
Beside the measured number, compound 4's estimate is 1.2-fold (0.06 log units) below it; measured number inside the range.
By their numbers in this assay, from the lowest: compounds 2, 3, 4 and 1 (each within the scatter of the next).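

In this assay, methyl in place of hydrogen on a saturated chain carbon, four bonds along the chain from an aromatic carbon, now gives no change at the digits printed from compound 3 to compound 4 (within the scatter), so this change has been read on two cores and stays small on both: the same change on two cores in this assay, a 1.2-fold lower number (0.09 log units; within the scatter) from compound 1 to compound 2 and no change at the digits printed (within the scatter) from compound 3 to compound 4, 1.2-fold (0.09 log units) apart, within the scatter of two such steps

The exchange of groups on the aromatic carbon can also be read a second time, as a 1.1-fold higher number from compound 2 to compound 4 (0.04 log units; within the scatter), and it too stays small: the same change on two cores in this assay, a 1.1-fold lower number (0.05 log units; within the scatter) from compound 1 to compound 3 and a 1.1-fold higher number (0.04 log units; within the scatter) from compound 2 to compound 4, 1.2-fold (0.09 log units) apart, within the scatter of two such steps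

From the compounds shown here alone, it remains open whether a much longer chain, or an amine or carboxylic acid on that chain, would keep the numbers this close.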